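The compounds below may be only part of what the source reports. "The series", "measured", "known", "first", "only" and "open" are said of these compounds alone.

Of the compounds shown here, three built on one shared core have been measured in an assay for binding affinity to Alpha-1B adrenergic receptor (Homo sapiens); on this read-out lower numbers stand for stronger inhibition and higher numbers for weaker inhibition. Compound 1 `CN1CCC[C@@H]1Cn1nc(Cc2ccc(F)c(F)c2)c2ccccc2c1=O` gives 316 nM. Compound 2 `CN1CCC[C@@H]1Cn1nc(Cc2ccc(C(C)(C)C)cc2)c2ccccc2c1=O` reaches only a limit, (the limit of > 1990 nM in this assay, at which 1 of the 3 values shown sits), so the value > 1990 nM for compound 2 is a limit and not a number. Compound 3 `CN1CCCCC(n2nc(Cc3ccc(Cl)cc3)c3ccccc3c2=O)C1` gives 158 nM, the lowest of the two numbers, yet compound 1 lies within the scatter of it, so no order between these two can be read. Compound 4 `CN1CCC(Cn2nc(Cc3ccc(Cl)cc3)c3ccccc3c2=O)C1` has not yet been measured. It differs from compound 3 in one place: (1-methylpyrrolidin-3-yl)methyl in place of 1-methylazepan-3-yl on an aromatic nitrogen. Among the measured compounds shown here, no measured pair shows this change, so its size is open; a shift near the scatter in either direction is expected. Compound 4 is estimated at 300 nM, with a range from 100 nM to 1000 nM. That estimate means an expected step of a 1.9-fold higher number from compound 3 to compound 4 (0.28 log units; within the scatter) in this assay.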

Compound 4, inhibition constant: 79.4 nM
Compound 4: middle estimate off by 3.8-fold (0.58 log units), on the high side, and the stated range ends above it.
By their numbers in this assay, from the lowest: compounds 4, 3 and 1 (each within the scatter of the next, the first and the last beyond it). At a limit, above all of these: compound 2.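

In this assay, putting (1-methylpyrrolidin-3-yl)methyl in place of 1-methylazepan-3-yl on the aromatic nitrogen gives a 2.0-fold lower number from compound 3 to compound 4 (0.30 log units; within the scatter), with the 4-chlorobenzyl group unchanged. This position therefore accepts both the five-membered and the seven-membered ring without a change beyond the scatter. Nothing shown here bears on the cause of this step. From the compounds shown here alone, whether an open-chain 2-(dimethylamino)ethyl group or a ring without a basic amine, such as tetrahydropyran-4-yl, would hold a similar number at this nitrogen stays open.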